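Secondary versus tertiary amine on the dichlorophenyl pyrimidine core

The compounds below may be only part of what the source reports. "The series", "measured", "known", "first", "only" and "open" are said of these compounds alone.

Compound 3 `CCCN(CC1CC1)c1nc(CC)c(-c2ccc(Cl)cc2Cl)nc1CC` gives 19.2 nM in an assay on IMR-32 cells for displacement of a labelled ligand from corticotropin-releasing factor receptor 1 (Homo sapiens), read by scintillation counting, with a stated time of 2 h (a lower number here means a stronger inhibitor, a higher number a weaker inhibitor), and stands lowest of the three numbers measured; compound 2 `CCc1nc(NC(CC)CC)c(F)nc1-c1ccc(Cl)cc1Cl` sits at 167 nM and compound 1 `CCc1nc(-c2ccc(Cl)cc2Cl)c(CC)nc1NC(COC)COC` at 224 nM, both beyond the scatter away from compound 3. The step now considered leads to compound 4 `CCc1nc(-c2ccc(Cl)cc2Cl)c(CC)nc1NC(CC)CC`, with the change ((pentan-3-yl)amino in place of (cyclopropylmethyl)(propyl)amino on an aromatic carbon). Within the data shown here, one measured step bears on it: a 12-fold lower number from compound 1 to compound 3 (1.07 log units; beyond the scatter), which also exchanged an amino group carrying a hydrogen-bond donor for the (cyclopropylmethyl)(propyl)amino group on the same core. On a core differing from compound 4 only in the fluorine, the (pentan-3-yl)amino group itself is carried by compound 2, which shows 167 nM. Both comparisons point the same way: the return to an amino group with one hydrogen-bond donor is expected to raise the number, by roughly the size seen in the reverse direction, so a 6.8-fold higher number from compound 3 to compound 4 (0.83 log units; beyond the scatter) is the estimated step. For compound 4 the expected value is 130 nM, within 45 nM to 400 nM.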

Compound 4, inhibition constant: 4.1 nM
Estimate against measurement, compound 4: 32-fold (1.50 log units) above; the measured number lies below the stated range.
By their numbers in this assay, from the lowest: compound 4; then compound 3; then compounds 2 and 1 (each within the scatter of the next).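

In this assay, the hydrogen-bond donor on this amino nitrogen carries no penalty of its own: (pentan-3-yl)amino in place of (cyclopropylmethyl)(propyl)amino gives a 4.7-fold lower number from compound 3 to compound 4 (0.67 log units; beyond the scatter), so compound 4 goes against the reading of the step from compound 1 to compound 3 as a donor effect. With the donor kept, the nitrogen substituent still matters, as pentan-3-yl in place of 2-methoxy-1-(methoxymethyl)ethyl gives a 55-fold lower number from compound 1 to compound 4 (1.74 log units; beyond the scatter), and the aromatic carbon holding ethyl in place of fluoro matters too, with a 41-fold lower number from compound 2 to compound 4 (1.61 log units; beyond the scatter). Nothing available here accounts for these steps.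

Still open, going by these compounds, is where a (cyclopropylmethyl)amino group, which keeps the donor and loses the propyl, would fall on the shared core. Also open, on these data alone, is how methyl or chloro in place of ethyl would read alongside (pentan-3-yl)amino.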